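The compounds below may be only part of what the source reports. "The series", "measured", "known", "first", "only" and "open" are said of these compounds alone.

In a functional assay on HL-60 cells (Homo sapiens) for cytotoxicity, read by WST assay, with a stated time of 48 h (a lower number here means that less compound is needed, a higher number that more compound is needed for the effect), compound 1 `O=C1OC[C@H](Cc2ccccc2)[C@H]1Cc1ccccc1O`, which has a hydrogen on an oxygen on an aromatic ring, gives 83000 nM. Compound 2 `CCCCOc1ccccc1C[C@H]1C(=O)OC[C@@H]1Cc1ccccc1`, with butyl in place of that hydrogen, gives 20000 nM. Compound 3 `CCCCCCCOc1ccccc1C[C@H]1C(=O)OC[C@@H]1Cc1ccccc1`, with heptyl there, gives 75000 nM. Compound 3 therefore stands level with compound 1 at the upper end of these numbers, while compound 2 lies apart from both, with a 3.8-fold higher number from compound 2 to compound 3 (0.57 log units; beyond the scatter).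

The next structure, compound 4 `O=C1OC[C@H](Cc2ccccc2)[C@H]1Cc1ccccc1F`, has fluoro in place of heptyloxy on an aromatic carbon, ortho to a large group (fluoro in place of heptyloxy on an aromatic carbon). Going by the values given here, no measured compound carries fluoro, so the evidence is indirect. The nearest guide is compound 1, which also lacks the heptyl chain, with a 1.1-fold lower number from compound 1 to compound 3 (0.04 log units; within the scatter). Butyl is the only change that moved the number beyond the scatter, with a 4.2-fold lower number from compound 1 to compound 2 (0.62 log units; beyond the scatter), and even that step was modest. With only these steps to go on, no clear direction can be given, and a step within the scatter is expected in this assay. The expected step is a 1.1-fold lower number from compound 3 to compound 4 (0.03 log units; within the scatter). Compound 4 is estimated at 70000 nM, with an expected range of 28000 nM to 170000 nM.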

Compound 4, half-maximal effective concentration: 72000 nM
The estimate for compound 4 lay 1.0-fold (0.01 log units) below the measured number; measured number inside the range.
By their numbers in this assay, from the lowest: compound 2; then compounds 4, 3 and 1 (each within the scatter of the next).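

In this assay, fluoro at this place on the aromatic ring, with 1 heavy atom, gives a number level with that of heptyloxy, with 8 heavy atoms (a 1.0-fold lower number from compound 3 to compound 4 (0.02 log units; within the scatter)), and level with that of hydroxy (a 1.2-fold lower number from compound 1 to compound 4 (0.06 log units; within the scatter)). Butoxy is now set apart from three different groups rather than two, and fluoro shows the same modest gap to it as heptyloxy does (a 3.6-fold higher number from compound 2 to compound 4 (0.56 log units; beyond the scatter)). Groups as different as fluoro, hydroxy and heptyloxy therefore share one level, so the size of the group does not order the numbers across these compounds, and compound 2 is the one that goes against that shared level.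

Nothing given here explains why butoxy alone departs from that level. On these data alone, it remains open whether shorter or intermediate ethers such as ethoxy, propoxy or hexyloxy would sit with butoxy or with the other groups, and whether an amine or a carboxylic acid at this place would leave the shared level at all.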